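Methyl in Place of Methoxy in a Cytotoxicity Series

A few compounds are considered here, and "the series" means these few. Any claim that something is new, unique, unknown or untested is made for them only; others in the source may bear on it.

Three compounds built on a shared core have been examined in an ADME assay on RD cells (Homo sapiens) for cytotoxicity; a lower number here means that less compound is tolerated, a higher number that more compound is tolerated. Compound 1 `Cc1cccc(NC(=O)N/N=C2\C(=O)Nc3ccccc32)c1`, compound 2 `COc1ccc2c(c1)/C(=N/NC(=S)Nc1ccccc1)C(=O)N2` and compound 3 `O=C1Nc2ccccc2/C1=N/NC(=S)N1CCCCC1` all come from this set. For compound 1 this assay reports only a limit, > 25000 nM. For compound 2 it likewise reports only a limit, > 25000 nM. For compound 3 too it reports only a limit, > 25000 nM. The whole picture so far is therefore (the limit of > 25000 nM in this assay, at which 3 of the 3 values shown sit), and compound 2 stands exactly where the other two stand, with no number of its own to place it higher or lower.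

Compound 4 `Cc1ccc2c(c1)/C(=N/NC(=S)Nc1ccccc1)C(=O)N2` differs from compound 2 by methyl in place of methoxy on an aromatic carbon. Within the data shown here, no measured pair in this set isolates such a change, so there is nothing to calibrate the step against. The step from compound 2 to compound 4 in this assay is expected to be a step that the limit leaves unreadable from compound 2 to compound 4, none beyond the scatter. Compound 4 is estimated at 30000 nM, between 12000 nM and 80000 nM, and most likely the assay will again report only a limit.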

Compound 4, half-maximal cytotoxic concentration: > 25000 nM
Compound 4 ended at the assay's limit; the forecaster's own chance of this, stated with the estimate: 85%; the middle value lies beyond the limit too.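

Compound 2 and compound 4 both end at a limit in this assay, so no step can be read between them: the limit of > 25000 nM in this assay, at which 4 of the 4 values shown sit. The compounds shown leave open where any of the four truly lies, and whether methyl in place of methoxy changes tolerance at all.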